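The compounds below may be only part of what the source reports. "The series", "measured", "known", "first", "only" and "open" are said of these compounds alone.

Compound 1 `CCC(=O)NC[C@@H]1CN(C)c2ccccc2[C@@H]1c1ccccc1` and compound 2 `CC(=O)NCC1Cc2ccccc2N(C)C1` have both been examined in a functional assay on cells with melatonin receptor type 1B (Homo sapiens) as the target, read by GTPgammaS binding, with a stated time of 1 h; a higher number here means a larger maximal response, a lower number a smaller maximal response. In this assay compound 1 gives 75%, while compound 2 gives 32%. Among the compounds with values here, compound 2 thus stands lowest of the two numbers, and its only neighbour, compound 1, lies beyond the scatter above it. Within the data shown here, no step between measured compounds that differ in one place is available, so the two values show only that compound 2 sits well below compound 1. Compound 3 `CCN1CC(CNC(C)=O)Cc2ccccc21` has not yet been measured in this assay. It differs from compound 2 by methyl in place of hydrogen on a saturated chain carbon bound to a nitrogen on an aromatic ring in a ring; cut one bond further out, the same difference reads methyl to ethyl. Among the measured compounds shown here, no measured pair shows the effect of such a change here. The step that the estimate means is a number 3 percentage points higher from compound 2 to compound 3 (within the scatter), expected to be none beyond the scatter. Compound 3 is accordingly estimated to give 35% in this assay, within a range from 15% to 60%.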

Compound 3, largest response reached (Emax), in percent of the reference or control that the assay uses: 59%
Estimate against measurement, compound 3: 24 percentage points below; the range from low to high includes it.
By their numbers in this assay, from the lowest: compound 2; then compound 3; then compound 1.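

In this assay, within the data shown here, methyl in place of hydrogen on a saturated chain carbon bound to a nitrogen on an aromatic ring in a ring gives a number 27 percentage points higher from compound 2 to compound 3 (beyond the scatter), the only one-place step measured in this set, and it shows that the maximal response is sensitive to a change at this position. Cut one bond further out, the same difference reads methyl to ethyl, so one added carbon at this place moves the response beyond the usual scatter. No measured evidence at hand accounts for this step.

The compounds shown leave open whether a longer chain such as propyl, or a branched group such as isopropyl, at this place would raise the response further or lower it. They also leave open whether the same step would hold with propionyl in place of acetyl on the amide nitrogen.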